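A Nitrophenyl Swap on the Saturated Ring Carbon

A few compounds are considered here, and "the series" means these few. Any claim that something is new, unique, unknown or untested is made for them only; others in the source may bear on it.

Compound 1 `COc1ccc(/C=C/C(=O)c2ccc(NC(=O)c3cc(Cl)ccc3OC)cc2)cc1` and compound 2 `COc1ccc(Cl)cc1C(=O)Nc1ccc(C(=O)/C=C/c2ccccc2[N+](=O)[O-])cc1` carry their two aryl groups on a chain of two double-bonded carbons, while compound 3 `COc1ccc(C2CC(c3ccc(NC(=O)c4cc(Cl)ccc4OC)cc3)=NN2C)cc1` carries them on a five-membered non-aromatic ring with 2 nitrogen. In a functional assay on the whole organism (plasma, strain albino) for inhibition, with Rattus norvegicus as the target, with stated times of 1 h and 4 h, at a dose of 25 mg/kg by the oral route (on this read-out higher numbers stand for a stronger effect at the one dose given and lower numbers for a weaker effect), compound 1 gives 68.1%, compound 2 gives 69.1%, and compound 3 gives 69.6%. Compound 3 therefore stands within the scatter of both compound 1 and compound 2, and no ranking among the three can be read from these numbers.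

Compound 4 `COc1ccc(Cl)cc1C(=O)Nc1ccc(C2=NN(C)C(c3ccccc3[N+](=O)[O-])C2)cc1` differs from compound 3 in one place: 2-nitrophenyl in place of 4-methoxyphenyl on a saturated ring carbon. Among the measured compounds shown here, the single measured step that bears on this change is the same exchange made on the chain, a number 1 percentage points higher from compound 1 to compound 2 (within the scatter). That step lay within the scatter, and the data give no sign that the saturated ring carbon would respond otherwise than the double-bonded chain carbon did. The expectation for compound 4 in this assay is accordingly a step of no size beyond the scatter, a number 0.4 percentage points higher from compound 3 to compound 4 (within the scatter). Compound 4 is estimated to give 70%, with a range from 60% to 80%.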

Compound 4, a percentage reported as inhibition, in the whole organism at one dose (the size of the read-out at that dose, not a potency): 83.8%
Compound 4: middle estimate off by 13.8 percentage points, on the low side; measured number outside the range, above it.
By their numbers in this assay, from the lowest: compounds 1, 2 and 3 (each within the scatter of the next); then compound 4.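

The exchange of 4-methoxyphenyl for 2-nitrophenyl on a saturated ring carbon gives a number 14.2 percentage points higher from compound 3 to compound 4 (beyond the scatter) in this assay whereas the same exchange on the chain gave a number 1 percentage points higher from compound 1 to compound 2 (within the scatter) and so stayed without a visible effect. Across these two pairs, then, the outcome of one and the same exchange differs with the place where it is made, and the step read on the chain did not carry over to the saturated ring carbon of the five-membered ring. Nothing measured here bears on why the two pairs part in this way.

On these data alone, the two pairs show only the swap between these two aryl groups, so it stays open whether the higher number in this assay belongs to the 2-nitrophenyl group in particular or would also come with a plain phenyl group or an aminophenyl group on the same ring carbon. As far as these compounds go, it also stays open whether the number would hold with an ethyl group or a longer chain in place of the methyl group on the ring, and, as the read-out reflects one dose only, how the compounds would compare at other doses.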